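A few compounds are considered here, and "the series" means these few. Any claim that something is new, unique, unknown or untested is made for them only; others in the source may bear on it.

In an ADME assay on HepG2 cells (Homo sapiens) for cytotoxicity, read by luminescence, CellTiter-Glo and ATP content, with a stated time of 72 h (a higher number here means that more compound is needed for the effect, a lower number that less compound is needed), compound 1 `COc1ccc(F)cc1CNCCCNc1ccnc2cc(Cc3ccc(C#N)cc3)ccc12` gives 6050 nM, the second highest of the three numbers measured. Compound 2 `Fc1ccc(Cc2ccc3c(NCCCNCc4ccco4)ccnc3c2)cc1` gives 5600 nM in this assay, and compound 3 `COc1cccc(CNCCCNc2ccnc3cc(Cc4ccc(C#N)cc4)ccc23)c1O` gives 7150 nM, so all three lie within the scatter of one another, and the step of a 1.2-fold higher number from compound 1 to compound 3 (0.07 log units; within the scatter) shows a change of the group on the saturated chain carbon bound to an amine nitrogen without effect beyond the scatter. Compound 4 `COc1ccc(F)cc1CNCCCNc1ccnc2cc(-c3ccc(C(C)(C)C)cc3)ccc12` differs from compound 1 at the core instead: 4-(tert-butyl)phenyl in place of 4-cyanobenzyl on an aromatic carbon. For the measured compounds named here, no measured step touches this position, so the measured steps give no guidance beyond the general narrowness of the numbers. Compound 4 is therefore expected to show a step of a 1.0-fold lower number from compound 1 to compound 4 (0.00 log units; within the scatter), within the scatter. Compound 4 is estimated at 6000 nM, in a range from 2500 nM to 15000 nM.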

Compound 4, half-maximal effective concentration: 620 nM
Beside the measured number, compound 4's estimate is 9.7-fold (0.99 log units) above it; measured number outside the range, below it.
By their numbers in this assay, from the lowest: compound 4; then compounds 2, 1 and 3 (each within the scatter of the next).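

The position on the aromatic carbon of the shared core, unlike the group on the chain carbon, moves the number in this assay: 4-(tert-butyl)phenyl in place of 4-cyanobenzyl gives a 9.8-fold lower number from compound 1 to compound 4 (0.99 log units; beyond the scatter), the only step shown beyond the scatter. This single change swaps benzyl for phenyl and nitrile for tert-butyl at once, and the step does not separate the two. Nothing at hand explains the step.

On these data alone, it remains open whether a cyanophenyl or a tert-butylbenzyl group would tell these two changes apart. Also open, as far as these compounds go, is how an amine or a carboxylic acid at this position would read.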